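The source may hold more compounds than are shown below. What is called first, only, known or untested is meant among the compounds shown, and "the series" means these compounds.

Measured so far:
compound 1, `COC(=O)N(C)CC#CCn1ccnc1`, 2 mg/kg
compound 2, `COC(=O)N(C)CC#CCn1cncc1C`, 4.5 mg/kg
compound 3, `CCOC(=O)N(C)CC#CCn1ccnc1`, which gives a limit of the assay, > 100 mg/kg

In a functional assay on the whole organism for agonist activity, with Mus musculus as the target (a lower number here means that less compound is needed, a higher number that more compound is needed for the effect), compound 1 gives 2 mg/kg. Compound 2 gives 4.5 mg/kg in this assay, and the change between the two is methyl in place of hydrogen on an aromatic carbon, which produced a 2.3-fold higher number from compound 1 to compound 2 (0.35 log units; beyond the scatter). The value of compound 3 in this assay is only a limit, > 100 mg/kg, and so the step from it is known as a bound only: an at least 50-fold higher number from compound 1 to compound 3 (1.69 log units; beyond the scatter). The two cores differ by methyl in place of hydrogen on a saturated chain carbon bound to an oxygen next to a carbonyl group. Compound 4, `CCOC(=O)N(C)CC#CCn1cncc1C`, has not yet been measured in this assay. It differs from compound 3 by methyl in place of hydrogen on an aromatic carbon, the same change that separates compound 1 from compound 2. Compound 4 is expected to show a step that the limit leaves unreadable from compound 3 to compound 4, resting on the earlier step of a 2.3-fold higher number from compound 1 to compound 2 (0.35 log units; beyond the scatter) and on the fact that compound 3 already sits at the limit of > 100 mg/kg in this assay, at which 1 of the 3 values shown sits. The estimated value for compound 4 in this assay is therefore 300 mg/kg, most plausibly between 100 mg/kg and 1500 mg/kg, and a further limit rather than a number is the likeliest outcome.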

Compound 4, dose for half-maximal effect: 97 mg/kg
Estimate against measurement, compound 4: 3.1-fold (0.49 log units) above, and the stated range ends above it.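

In this assay compound 3 stands at a limit of the assay, > 100 mg/kg. On its core, methyl in place of hydrogen on an aromatic carbon gives an at least 1.0-fold lower number from compound 3 to compound 4 (0.01 log units; that floor lies within the scatter), a bound that neither confirms nor rules out a repeat of the earlier step: the same change on two cores in this assay, a 2.3-fold higher number (0.35 log units; beyond the scatter) from compound 1 to compound 2 and an at least 1.0-fold lower number (0.01 log units; that floor lies within the scatter) from compound 3 to compound 4; the limit leaves it open whether they differ The other change, methyl in place of hydrogen on a saturated chain carbon bound to an oxygen next to a carbonyl group, is large on both cores, and a 22-fold higher number from compound 2 to compound 4 (1.33 log units; beyond the scatter) gives it a firm size on the second core, though an exact match between the two cores is not shown: the same change on two cores in this assay, an at least 50-fold higher number (1.69 log units; beyond the scatter) from compound 1 to compound 3 and a 22-fold higher number (1.33 log units; beyond the scatter) from compound 2 to compound 4; the limit leaves it open whether they differ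

The compounds shown leave open how a longer chain on the oxygen next to the carbonyl group, such as propyl, would read in this assay. They also leave open what an ethyl group would do in place of the methyl on the aromatic carbon.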